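Notes on compound 4 against three measured analogues

The source may report more compounds than this note shows. Statements on the series, on what has been measured and on what is new or still open speak of the compounds shown alone.

Of the compounds shown here, three have been measured in a functional assay on HT-1080 cells (Homo sapiens), read by transwell migration, with a stated time of 24 h, tested at 1 uM; a lower number here means a stronger effect, a higher number a weaker effect of the compound at the concentration tested. Compound 1 `CC(=O)OCc1ccc2oc(=O)c(C(=O)N(C)c3ccccc3Cl)cc2c1` gives 62.8%, and compound 2 `CC(=O)OCc1ccc2oc(=O)c(C(=O)N(C)c3ccc(Cl)cc3)cc2c1` gives 98.6%. Among the measured compounds shown here, the only single-point step among the measured compounds, a number 35.8 percentage points higher from compound 1 to compound 2 (beyond the scatter), concerns the aryl ring on the amide-type nitrogen. Compound 3 `CCCC(=O)OCc1ccc2oc(=O)c(C(=O)Oc3cccc(Br)c3)cc2c1` gives 50.5% and so stands lowest of the three numbers, beyond the scatter from both compound 1 and compound 2; on the read-out of this assay that is the strongest effect recorded so far.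

Compound 4 `CC(C)(C)C(=O)OCc1ccc2oc(=O)c(C(=O)Oc3cccc(Br)c3)cc2c1` differs from compound 3 in one place only: tert-butyl in place of propyl on a carbonyl carbon. For the measured compounds named here, no measured step touches this part of the molecule; the one step available, from compound 1 to compound 2, changes the aryl ring on the amide-type nitrogen and is not informative about a tert-butyl in place of propyl on a carbonyl carbon. With nothing bearing on the change, a step of no size beyond the scatter is expected, in neither direction, so that no change at the digits printed from compound 3 to compound 4 (within the scatter) is the estimated step. For compound 4 the expected value in this assay is therefore 50.5%, estimated to lie between 36% and 66%.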

Compound 4, a percentage reported as activity, at one concentration (the size of the read-out at that concentration, not a potency): 48.2%
Estimate against measurement, compound 4: 2.3 percentage points above; low and high end bracket the measured number.
By their numbers in this assay, from the lowest: compounds 4 and 3 (each within the scatter of the next); then compound 1; then compound 2.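

Among the compounds shown here, the first measured change at this part of the molecule, tert-butyl in place of propyl on a carbonyl carbon, gives in this assay a number 2.3 percentage points lower from compound 3 to compound 4 (within the scatter), so the read-out does not separate these two groups in this pair. For the compounds shown here, this position therefore accepts a tert-butyl group without a change beyond the scatter, whereas the only other measured step, a number 35.8 percentage points higher from compound 1 to compound 2 (beyond the scatter), comes from the aryl ring on the amide-type nitrogen and lies beyond the scatter. No available evidence bears on this result.

Still open, going by these compounds, is whether this flat response extends to other groups on the same carbonyl carbon, such as a longer chain like hexyl, a phenyl ring, or a chain ending in an amine or a carboxylic acid. Also open, on these data alone, is whether tert-butyl in place of propyl behaves alike on compounds with the amide-type nitrogen, such as compound 1, and whether a read-out at a single concentration would still fail to separate the pair at other concentrations.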